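The compounds below may be only part of what the source reports. "The series", "measured", "known", "first", "only" and "open" are said of these compounds alone.

In a functional assay on HeLa cells (Homo sapiens) for antiproliferative activity, read by CCK-8 assay, with a stated time of 48 h (a lower number here means a stronger inhibitor, a higher number a weaker inhibitor), three compounds sharing one core have been read. Compound 1 `COc1ccc(/C=C\c2cc(OC)c(OC)c(OC)c2)cc1OCc1ccc(CN2CCCC[C@H]2C(=O)O)cc1` gives > 10000 nM, which is a limit of the assay and not a number. Compound 2 `COc1ccc(/C=C\c2cc(OC)c(OC)c(OC)c2)cc1OCc1ccc(CN2CC[C@H](O)C2)cc1` gives 10500 nM, and compound 3 `COc1ccc(/C=C\c2cc(OC)c(OC)c(OC)c2)cc1OCc1ccc(CN2CC[C@@H](C(=O)O)C2)cc1` gives 12800 nM. For the measured compounds named here, the one readable step, a 1.2-fold higher number from compound 2 to compound 3 (0.09 log units; within the scatter), places compound 3 level with the only other exact number in the set.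

Compound 4 `COc1ccc(/C=C\c2cc(OC)c(OC)c(OC)c2)cc1OCc1ccc(CN2CCCCC2C(=O)NCCN)cc1` carries 2-((2-aminoethyl)carbamoyl)piperidin-1-yl in place of 3-carboxypyrrolidin-1-yl on a saturated chain carbon bound to an aromatic carbon. Going by the values given here, the closest precedent is compound 1, which also has a substituted piperidine, but a step that the limit leaves unreadable from compound 1 to compound 3 gives no size, and neither does a step that the limit leaves unreadable from compound 1 to compound 2. Both rest on (the limit of > 10000 nM in this assay, at which 1 of the 3 values shown sits). Among the compounds with values here, the readable step between hydroxy and carboxy pyrrolidines, a 1.2-fold higher number from compound 2 to compound 3 (0.09 log units; within the scatter), shows no movement, but it does not test the aminoethyl amide, and no measured compound carries that group. With compound 2 and compound 3 together and compound 1 reported only as a limit, no step beyond the scatter is expected in this assay. The expected change is a 1.3-fold lower number from compound 3 to compound 4 (0.11 log units; within the scatter). For compound 4 the estimated value is 10000 nM, with an expected range from 2000 nM to 25000 nM.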

Compound 4, half-maximal inhibitory concentration: 7300 nM
For compound 4 the middle estimate is 1.4-fold (0.14 log units) above the measured one; low and high end bracket the measured number.
By their numbers in this assay, from the lowest: compounds 4, 2 and 3 (each within the scatter of the next).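

In this assay, putting 2-((2-aminoethyl)carbamoyl)piperidin-1-yl on a saturated chain carbon bound to an aromatic carbon gives a 1.8-fold lower number from compound 3 to compound 4 (0.24 log units; within the scatter) and a 1.4-fold lower number from compound 2 to compound 4 (0.16 log units; within the scatter), so the aminoethyl amide on a six-membered ring reads level with both pyrrolidines, and this place tolerates a change of ring, of ring substituent and of chain with no step beyond the scatter. The comparison with the 2-carboxypiperidin-1-yl group gives an at least 1.3-fold lower number from compound 1 to compound 4 (0.13 log units; that floor lies within the scatter), which sets the amide against the carboxylic acid on the same ring, though only as a floor. For compound 1 the reading > 10000 nM is a limit, and the step tied to it has no upper size: the limit of > 10000 nM in this assay, at which 1 of the 4 values shown sits.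

As far as these compounds go, whether a longer chain on the amide, a dimethylamino group at its end or an unsubstituted piperidine would read any differently in this assay stays open. Also open, from the compounds shown here alone, is whether any group at this place can give a step beyond the scatter, as every step that can be read so far lies within it.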